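Adding a Fluoro Group to a Weak Cytotoxic Pyridazinone Amide

The source may hold more compounds than are shown below. What is called first, only, known or untested is meant among the compounds shown, and "the series" means these compounds.

Of the compounds shown here, three built on one shared scaffold have been tested in a functional assay on HepG2 cells (Homo sapiens) for cytotoxicity, read by MTT assay, with a stated time of 72 h; a higher number here means a weaker inhibitor, a lower number a stronger inhibitor. Compound 1 `Cc1cc(=O)n(-c2ccc(F)c(F)c2)nc1C(=O)Nc1ccc(Oc2ncnc3ccsc23)c(F)c1` gives 6930 nM. Compound 2 `Cc1cc(=O)n(-c2ccc(Br)cc2F)nc1C(=O)Nc1ccc(Oc2ncnc3sccc23)c(F)c1` gives 13800 nM. Compound 3 `Cc1cc(=O)n(-c2cccc(F)c2)nc1C(=O)Nc1ccc(Oc2ncnc3sccc23)c(F)c1` gives 24500 nM, the highest of the three numbers; compound 2 sits nearest to it, while compound 1 sits furthest away, beyond the scatter.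

Within the data shown here, the only measured step that changes a single place is a 1.8-fold higher number from compound 2 to compound 3 (0.25 log units; within the scatter), which swaps one substituted phenyl group on an aromatic nitrogen for another and stays within the scatter.

Compound 4 `Cc1cc(=O)n(-c2ccc(F)c(F)c2)nc1C(=O)Nc1ccc(Oc2ncnc3sccc23)c(F)c1` is compound 3 with one further change: fluoro in place of hydrogen on an aromatic carbon. Among the measured compounds shown here, no measured pair shows exactly this change. Compound 1 carries the same 3,4-difluorophenyl group as compound 4 but differs from it elsewhere in the shared core. In this assay compound 1 gives 6930 nM, a lower number than that of compound 3. That is the only hint available, and it does not isolate the added fluoro group.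

Taking the small size of the one measured step together with the lower number of compound 1, compound 4 is expected to fall somewhat below compound 3, a step of about a 2.0-fold lower number from compound 3 to compound 4 (0.31 log units; beyond the scatter). The estimated value for compound 4 in this assay is 12000 nM, with a likely range from 5000 nM to 30000 nM.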

Compound 4, half-maximal inhibitory concentration: > 40000 nM
Compound 4: no number, only a limit; the forecaster's own chance of this, stated with the estimate: 10%; middle value at least 3.3-fold (0.52 log units) from the limit.
By their numbers in this assay, from the lowest: compounds 1, 2 and 3 (each within the scatter of the next, the first and the last beyond it). At a limit, above all of these: compound 4.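

In this assay compound 4 gives no number, only a limit of the assay: the limit of > 40000 nM in this assay, at which 1 of the 4 values shown sits. Going from 3-fluorophenyl to 3,4-difluorophenyl, with the new fluoro group ortho to the existing fluoro group and para to a large group, gives an at least 1.6-fold higher number from compound 3 to compound 4 (0.21 log units; that floor lies within the scatter), so this change offers no sign of a lower number, although that floor alone does not separate the two compounds. The other two steps are clearer: an at least 2.8-fold higher number from compound 2 to compound 4 (0.46 log units; beyond the scatter) shows that this phenyl group compares unfavourably with 4-bromo-2-fluorophenyl on the shared core, while an at least 5.7-fold higher number from compound 1 to compound 4 (0.76 log units; beyond the scatter) shows that the 3,4-difluorophenyl group does not bring a low number with it, since the result depends on the group on the oxygen as well.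

On these data alone, how far beyond its limit the true value of compound 4 lies stays open, so the full size of all three steps is unknown. Also open, as far as these compounds go, is whether a methoxy group or an amine in place of the added fluoro group would move the number down, up or not at all.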